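The source may report more compounds than this note shows. Statements on the series, on what has been measured and on what is new or still open speak of the compounds shown alone.

Compound 1 `CS(=O)(=O)c1ccc(-c2cnc3[nH]cc(-c4nnc(-c5ccc(F)cc5)o4)c(=O)c3c2)cc1` and compound 2 `CS(=O)(=O)c1ccc(-c2cnc3[nH]cc(-c4nnc(-c5cccnc5)o4)c(=O)c3c2)cc1` share one core and differ only at the group on the five-membered aromatic ring. In a functional assay on HCT-116 cells (Homo sapiens) for inhibition, read by MTT assay, with a stated time of 24 h, tested at 5 uM (on this read-out higher numbers stand for more inhibition of growth at the one concentration tested and lower numbers for less inhibition of growth), compound 1 gives 14.9% and compound 2 gives 9.26%; the step of a number 5.6 percentage points lower from compound 1 to compound 2 (within the scatter) is within the scatter, and compound 2 stands as the lower of the two numbers, the two being indistinguishable. Compound 3 `Cc1cccc(-c2nnc(-c3c[nH]c4ncc(-c5ccc(S(C)(=O)=O)cc5)cc4c3=O)o2)c1` carries 3-methylphenyl in place of pyridin-3-yl on an aromatic carbon. For the measured compounds named here, the only step that bears on this change is a number 5.6 percentage points lower from compound 1 to compound 2 (within the scatter), which did not exceed the scatter, so no step beyond the scatter is expected in this assay for compound 3, estimated as a number 3.7 percentage points higher from compound 2 to compound 3 (within the scatter). The estimate for compound 3 is 13%, expected between 2% and 26%.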

Compound 3, percent growth inhibition at one concentration: 20.4%
Beside the measured number, compound 3's estimate is 7.4 percentage points below it; low and high end bracket the measured number.
By their numbers in this assay, from the lowest: compounds 2, 1 and 3 (each within the scatter of the next, the first and the last beyond it).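

At the group on the five-membered aromatic ring, this assay now shows a change beyond the scatter for 3-methylphenyl in place of pyridin-3-yl (a number 11.1 percentage points higher from compound 2 to compound 3 (beyond the scatter)). The same 3-methylphenyl group in place of 4-fluorophenyl stays within the scatter (a number 5.5 percentage points higher from compound 1 to compound 3 (within the scatter)), so the 4-fluorophenyl and 3-methylphenyl groups cannot be told apart here. No available data explain the modest step from pyridin-3-yl.

Open, going by these compounds, is whether any group at this position lifts growth inhibition further. A carboxylic acid or an amine in place of the aromatic group would test how far this position tolerates change.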